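Cytotoxicity of a nitroimidazooxazine series: compound 4 expected

The source may hold more compounds than are shown below. What is called first, only, known or untested is meant among the compounds shown, and "the series" means these compounds.

Measured compounds:
- compound 1, `C[C@]1(CN2CCc3nc(N4CCCCC4)ccc3C2)Cn2cc([N+](=O)[O-])nc2O1`: "not determined" (no result reported)
- compound 2, `C[C@]1(CN2CCc3nc(-c4ccccc4F)ccc3C2)Cn2cc([N+](=O)[O-])nc2O1`: > 32 ug/mL
- compound 3, `C[C@]1(CN2CCc3nc(-c4ccc(C(F)(F)F)cc4)ccc3C2)Cn2cc([N+](=O)[O-])nc2O1`: > 32 ug/mL

These three compounds share one core and differ only in the group attached to an aromatic carbon of that core. In an ADME assay on Vero cells (Chlorocebus sabaeus) for cytotoxicity, read by MTT assay, with a stated time of 72 h (on this read-out lower numbers stand for higher toxicity in this test and higher numbers for lower toxicity in this test), compound 1 has no reported result, so it stands nowhere on the numbers shown; its value is simply "not determined" (no result reported). For compound 2 the value > 32 ug/mL is a limit of the assay, not a number. For compound 3 likewise the value > 32 ug/mL is a limit and not a number. For the measured compounds named here, the step that the two limits leave unreadable from compound 2 to compound 3 therefore cannot be read, and it is the only measured step available; it bears on compound 4 only insofar as both of its end points sit at the limit, as the limit of > 32 ug/mL in this assay, at which 2 of the 3 values shown sit, records.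

Compound 4, `C[C@]1(CN2CCc3nc(-c4cc(F)c(F)c(F)c4)ccc3C2)Cn2cc([N+](=O)[O-])nc2O1`, is not yet measured. It differs from compound 1 by 3,4,5-trifluorophenyl in place of piperidin-1-yl on an aromatic carbon. Going by the values given here, no measured step covers this exchange, so no size or direction of change can be drawn from the data. Because both aryl-bearing compounds sit at the limit of > 32 ug/mL in this assay, at which 2 of the 3 values shown sit, compound 4 is expected to behave like them, with an estimated value of 40 ug/mL, in the range 20 ug/mL to 100 ug/mL, most likely again reported only as a limit.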

Compound 4, half-maximal cytotoxic concentration: > 32 ug/mL
Compound 4: only a limit was reported (the forecaster's own chance of this, stated with the estimate: 75%); the middle value does not contradict the limit.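

Compound 2, compound 3 and compound 4 all sit at a limit rather than at a number, so no step among them can be read in this assay: the limit of > 32 ug/mL in this assay, at which 3 of the 4 values shown sit.

The compounds shown leave open how these three truly compare, and whether any group at this place on the shared core would give a readable number.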